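A few compounds are considered here, and "the series" means these few. Any claim that something is new, unique, unknown or untested is made for them only; others in the source may bear on it.

Working notes on a small series of hydroxamic acids. Compound 1 `CN1CCN(c2ccc(C(=O)/C=C/c3cccc(/C=C/C(=O)NO)c3)cc2)CC1` and compound 2 `O=C(/C=C/c1cccc(/C=C/C(=O)c2ccccc2)c1)NO` share one core; compound 3 `CN1CCN(c2ccc(C(=O)/C=C/c3ccc(/C=C/C(=O)NO)cc3)cc2)CC1` and compound 4 `O=C(/C=C/c1ccc(/C=C/C(=O)c2ccccc2)cc1)NO` share another, and the difference between the two cores is not broken down here. In a physicochemical assay for solubility, at pH 7.4 (on this read-out lower numbers stand for lower solubility and higher numbers for higher solubility), compound 1 gives 15000 nM and compound 2 gives 12000 nM; the change hydrogen in place of 4-methylpiperazin-1-yl on an aromatic carbon produced a 1.3-fold lower number from compound 1 to compound 2 (0.10 log units; within the scatter). In this assay compound 3 gives 1000 nM, the lowest of the three numbers and beyond the scatter from both compound 1 and compound 2. Compound 4 carries the same change on the other core, (hydrogen in place of 4-methylpiperazin-1-yl on an aromatic carbon), and the place of the change matches that of the earlier pair word for word. Among the measured compounds shown here, the step from compound 3 to compound 4 in this assay is estimated as a 1.2-fold lower number from compound 3 to compound 4 (0.07 log units; within the scatter), resting on the single precedent, because a 1.3-fold lower number from compound 1 to compound 2 (0.10 log units; within the scatter) lay within the scatter. Compound 4 is therefore expected to give about 850 nM in this assay. The expected range for compound 4 runs from 400 nM to 1800 nM.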

Compound 4, solubility: 3000 nM
Estimate against measurement, compound 4: 3.5-fold (0.55 log units) below; the measured number lies above the stated range.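

In this assay the change to hydrogen in place of 4-methylpiperazin-1-yl gives a 3.0-fold higher number from compound 3 to compound 4 (0.48 log units; beyond the scatter) on one core, against a 1.3-fold lower number from compound 1 to compound 2 (0.10 log units; within the scatter) on the other, so the step seen on the core of compound 1 did not carry over to the core of compound 3. This shows that, across these four compounds, the same change at the same place does not give a step of the same size on both cores; two pairs set no rule, however, and they do not show how the change would behave on any further core. No measurement at hand bears on why the two pairs differ. The compounds shown leave open how either core responds when 4-methylpiperazin-1-yl gives way to another amine, such as morpholin-4-yl or dimethylamino, or to a carboxylic acid. They also leave open what a longer chain carrying the same amine would do on each core.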